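Turning One Ring Centre in a Lipid-Chain Aminosugar

The source may hold more compounds than are shown below. What is called first, only, known or untested is meant among the compounds shown, and "the series" means these compounds.

Compound 1: `CCCCCCCCCCCNC[C@@H]1OC[C@H](N)[C@H]1O` — in this assay 88800 nM
Compound 2: `CCCCCCCCCCNC[C@@H]1OC[C@H](N)[C@H]1O` — in this assay a limit, > 128000 nM
Compound 3: `CCCCCCCCCCCCCCNC[C@@H]1OC[C@H](N)[C@@H]1O` — in this assay 14300 nM

In a functional assay on B16-F10 cells (Mus musculus) for antiproliferative activity, read by MTT assay, with a stated time of 72 h (a lower number here means a stronger inhibitor, a higher number a weaker inhibitor), compound 3 gives 14300 nM, the lowest of the two numbers that are available. Compound 1 gives 88800 nM, a clearly higher number than compound 3. Among the measured compounds shown here, compound 2 gives only > 128000 nM, which is a limit of the assay rather than a number; it is the one value that sits at the limit of > 128000 nM in this assay, at which 1 of the 3 values shown sits. For the measured compounds named here, the only step between measured compounds, an at least 1.4-fold higher number from compound 1 to compound 2 (0.15 log units; that floor lies within the scatter), shortens the chain and lies within the scatter.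

Compound 4, `CCCCCCCCCCCCCCNC[C@@H]1OC[C@H](N)[C@H]1O`, keeps the chain of compound 3 and differs from it only in how one ring carbon is drawn: the two compounds have the same atoms and bonds and differ only in configuration as drawn: 1 of 3 stereo elements differ; a stereocentre at a saturated ring carbon is drawn S in compound 3 and R in compound 4. Going by the values given here, no measured pair differs in configuration alone, so none of the measured steps bears directly on this change. With the chain unchanged, the expectation is that the step of a 1.4-fold higher number from compound 3 to compound 4 (0.15 log units; within the scatter) stays small and gives no clear direction beyond the scatter. Compound 4 is therefore estimated at 20000 nM, with a plausible range from 7000 nM to 60000 nM.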

Compound 4, half-maximal inhibitory concentration: 64300 nM
Estimate against measurement, compound 4: 3.2-fold (0.51 log units) below; measured number above the stated range.
By their numbers in this assay, from the lowest: compound 3; then compounds 4 and 1 (each within the scatter of the next). At a limit, above all of these: compound 2.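

In this assay, turning this one ring centre moves the number beyond the scatter, a 4.5-fold higher number from compound 3 to compound 4 (0.65 log units; beyond the scatter), so at this saturated ring carbon the form drawn S is the stronger inhibitor of the pair, and the step can be tied to that centre alone because nothing else separates the two: the fact that compounds 3 and 4 differ only in the configuration as drawn

Among the compounds shown here, with the centre drawn R, the chain gives no such clear step: for propyl in place of hydrogen, a 1.4-fold lower number from compound 1 to compound 4 (0.14 log units; within the scatter), the change stays within the scatter, so the configuration matters more here than that chain difference does. Compound 2 stands at a limit, which means that the step for butyl in place of hydrogen, an at least 1.9-fold lower number from compound 2 to compound 4 (0.29 log units; that floor lies within the scatter), gives only a floor and not a size: the limit of > 128000 nM in this assay, at which 1 of the 4 values shown sits.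

Compound 3 and compound 4 are the only pair shown that differs in configuration alone, so it remains open whether turning this centre would matter as much with a shorter chain. Also open, as far as these compounds go, is how a longer chain, or an amide in place of the chain amine, would behave with either form of the ring centre.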